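Removing a Methoxy Group in Two Different Places

The source may hold more compounds than are shown below. What is called first, only, known or untested is meant among the compounds shown, and "the series" means these compounds.

Measured so far:
Compound 1, `COc1ccn2c(-c3ccc(NC(=O)c4ccc([N+](=O)[O-])o4)cc3)cnc2c1`: 860 nM
Compound 2, `COc1ccn2c(-c3ccc(NC(=O)c4ccc([N+](=O)[O-])o4)cc3C)cnc2c1`: 1030 nM
Compound 3, `COc1ccn2c(-c3ccc(NC(=O)c4ccc([N+](=O)[O-])o4)c(OC)c3)cnc2c1`: 7520 nM

In a functional assay on MGC-803 cells (Homo sapiens) for antiproliferative activity, read by CCK-8 assay, with a stated time of 72 h (on this read-out higher numbers stand for weaker inhibition and lower numbers for stronger inhibition), compound 3 gives the highest of the three numbers, and the step of an 8.7-fold lower number from compound 3 to compound 1 (0.94 log units; beyond the scatter) lies beyond the scatter. This change is hydrogen in place of methoxy on an aromatic carbon. By contrast, the step of a 1.2-fold higher number from compound 1 to compound 2 (0.08 log units; within the scatter) is within the scatter, so compounds 1 and 2 are not distinguished by this assay.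

Compound 4, `Cc1cc(NC(=O)c2ccc([N+](=O)[O-])o2)ccc1-c1cnc2ccccn12`, has not yet been measured. It differs from compound 2 by hydrogen in place of methoxy on an aromatic carbon. Among the measured compounds shown here, this is the same kind of change as the one between compound 3 and compound 1, but not the same change: there the methoxy left an aromatic carbon of a six-membered aromatic ring of carbon only, ortho to a large group and meta to a large group, whereas here it leaves a six-membered aromatic ring with one nitrogen that is part of a fused system of two rings, meta and para to the fused ring and opposite the ring nitrogen. The difference between the core of compound 2 and the core of compound 3 is not broken down here.

Because the earlier step of an 8.7-fold lower number from compound 3 to compound 1 (0.94 log units; beyond the scatter) came from a different place, it gives only a weak guide. Compound 4 is expected to show a smaller step, a 1.3-fold higher number from compound 2 to compound 4 (0.10 log units; within the scatter), in this assay. Compound 4 is therefore estimated at 1300 nM, between 400 nM and 4500 nM.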

Compound 4, half-maximal inhibitory concentration: 900 nM
For compound 4 the middle estimate is 1.4-fold (0.16 log units) above the measured one, within the range that was stated.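

In this assay, the loss of the methoxy from the six-membered aromatic ring with one nitrogen, part of the fused system, gives a 1.1-fold lower number from compound 2 to compound 4 (0.06 log units; within the scatter), so this read-out does not separate that pair. Set beside the earlier exchange of methoxy for hydrogen, the result shows that this change cannot be carried from one core to another at a fixed size, since the two steps differ by more than the scatter allows: the same change on two cores in this assay, an 8.7-fold lower number (0.94 log units; beyond the scatter) from compound 3 to compound 1 and a 1.1-fold lower number (0.06 log units; within the scatter) from compound 2 to compound 4, 7.6-fold (0.88 log units) apart, beyond the scatter of two such steps What this does not show is whether the difference follows the place the methoxy leaves or the rest of the core, since the two steps differ in both, and two steps make no rule for the series.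

The compounds shown leave open how the same exchange would read with the methoxy leaving the same place on two otherwise different cores, which would separate those two explanations. They also leave open whether an amine, a fluorine or an ethoxy on the aromatic carbon opposite the ring nitrogen would read like the hydrogen of compound 4 or the methoxy of compound 2, or differently from both.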